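The source may hold more compounds than are shown below. What is called first, only, known or untested is meant among the compounds shown, and "the series" means these compounds.

Working notes on the series in a functional assay on ACHN cells (Homo sapiens) for antiproliferative activity, read by sulforhodamine B assay; a higher number here means a weaker inhibitor of growth, a lower number a stronger inhibitor of growth. Compound 1 `CCCCCCOc1cccc(O)c1C(=O)/C=C/c1ccc(O)cc1` gives > 30000 nM, which is a limit of the assay. Compound 2 `O=C(/C=C/c1ccc(O)cc1)c1c(O)cccc1OCC1CCCC1` gives 3510 nM and compound 3 `CC(C)CCOc1cccc(O)c1C(=O)/C=C/c1ccc(O)cc1` gives 11300 nM, so compound 3 holds the higher of the two actual numbers.

Compound 4 `O=C(/C=C/c1ccc(O)cc1)c1c(O)cccc1OCc1ccccc1` has phenyl in place of isobutyl on a saturated chain carbon bound to an oxygen on an aromatic ring. Going by the values given here, the closest precedent is a 3.2-fold higher number from compound 2 to compound 3 (0.51 log units; beyond the scatter), which swaps cyclopentyl for isobutyl at that same place. Read in reverse, it points to a modest drop for a ring there. an at least 8.5-fold lower number from compound 1 to compound 2 (0.93 log units; beyond the scatter) and an at least 2.6-fold lower number from compound 1 to compound 3 (0.42 log units; beyond the scatter) also favour compound 2 over compound 3.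

The expected change is a 2.5-fold lower number from compound 3 to compound 4 (0.40 log units; beyond the scatter). For compound 4 the estimated value is 4500 nM, within a range of 1500 nM to 14000 nM.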

Compound 4, concentration for 50% growth inhibition: > 30000 nM
Compound 4: only a limit was reported (the forecaster's own chance of this, stated with the estimate: 5%); at least 6.6-fold (0.82 log units) between middle value and limit.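

In this assay compound 4 gives > 30000 nM, which is a limit of the assay. A ring on the saturated chain carbon bound to an oxygen on an aromatic ring is therefore not enough on its own: an at least 2.6-fold higher number from compound 3 to compound 4 (0.42 log units; beyond the scatter) and an at least 8.5-fold higher number from compound 2 to compound 4 (0.93 log units; beyond the scatter), so cyclopentyl and phenyl do not read alike here. The step from compound 1 to compound 4 cannot be read, as the two compounds share the ceiling: the limit of > 30000 nM in this assay, at which 2 of the 4 values shown sit.

On these data alone, whether cyclohexyl at this place reads like cyclopentyl or like phenyl stays open. So does how far compound 1 and compound 4 lie past the limit.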